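Compound 3 to compound 4: a benzyl aryl swap

The source may hold more compounds than are shown below. What is called first, only, known or untested is meant among the compounds shown, and "the series" means these compounds.

In an ADME assay on HaCaT cells (Homo sapiens) for cytotoxicity, read by MTT assay, with a stated time of 72 h (on this read-out higher numbers stand for weaker inhibition and lower numbers for stronger inhibition), compound 3 `Cc1cc(S(=O)(=O)/N=C(\N)n2nccc2-c2ccccc2)c(SCc2cccc(Cl)c2)cc1Cl` gives 10000 nM, the lowest of the three numbers. Compound 1 `Cc1cc(-c2ccccc2)n(/C(N)=N/S(=O)(=O)c2cc(C)c(Cl)cc2SCc2cccc3ccccc23)n1` gives 12000 nM, which lies within the scatter of compound 3, whereas compound 2 `Cc1ccc(CSc2cc(Cl)c(C)cc2S(=O)(=O)/N=C(\N)n2nc(C)cc2-c2ccccc2)cc1` gives 30000 nM, beyond it. Compound 4 `Cc1cc(S(=O)(=O)/N=C(\N)n2nccc2-c2ccccc2)c(SCc2ccc(C(F)(F)F)cc2)cc1Cl` differs from compound 3 by 4-(trifluoromethyl)phenyl in place of 3-chlorophenyl on a saturated chain carbon bound to a sulfur. For the measured compounds named here, one measured step bears on this: a 2.5-fold higher number from compound 1 to compound 2 (0.40 log units; beyond the scatter), also an exchange of the aryl group on a saturated chain carbon bound to a sulfur, and it was modest. A shift of similar size, in either direction, is therefore expected here, and the step is estimated as a 1.3-fold higher number from compound 3 to compound 4 (0.11 log units; within the scatter). Compound 4 is expected to give 13000 nM, with a range from 6000 nM to 30000 nM.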

Compound 4, half-maximal inhibitory concentration: 19000 nM
The estimate for compound 4 lay 1.5-fold (0.16 log units) below the measured number; the range from low to high includes it.
By their numbers in this assay, from the lowest: compounds 3, 1, 4 and 2 (each within the scatter of the next, the first and the last beyond it).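

In this assay the exchange gives a 1.9-fold higher number from compound 3 to compound 4 (0.28 log units; within the scatter) and so leaves 3-chlorophenyl and 4-(trifluoromethyl)phenyl at this place not told apart. Set against a 2.5-fold higher number from compound 1 to compound 2 (0.40 log units; beyond the scatter) as the only other step here, it shows that an aryl exchange on a saturated chain carbon bound to a sulfur need not move the number beyond the scatter. Nothing measured here gives a cause for either step.

As far as these compounds go, it remains open whether an amine or a carboxylic acid on this aryl ring, or a longer chain between the sulfur and the ring, would move the number beyond the scatter.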